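A few compounds are considered here, and "the series" means these few. Any claim that something is new, unique, unknown or untested is made for them only; others in the source may bear on it.

Measured in a functional assay on A549 cells (Homo sapiens) for antiproliferative activity, read by MTT assay, with a stated time of 24 h; a higher number here means a weaker inhibitor, a lower number a stronger inhibitor:
- Compound 1 `O=C(NNc1ccccc1Cl)c1ccc(NS(=O)(=O)c2cnc(O)nc2O)cc1`: 3340 nM
- Compound 2 `Cc1ccccc1NNC(=O)c1ccccc1NS(=O)(=O)c1cnc(O)nc1O`: > 20000 nM, a limit of the assay
- Compound 3 `O=C(NNc1ccccc1Cl)c1ccccc1NS(=O)(=O)c1cnc(O)nc1O`: 5480 nM

Compound 3 and compound 1 lie within the scatter of each other. Compound 4 `O=C(NNc1ccc(F)cc1)c1ccccc1NS(=O)(=O)c1cnc(O)nc1O` differs from compound 3 at one place, with 4-fluorophenyl in place of 2-chlorophenyl on an amine nitrogen. For the measured compounds named here, the only measured step on this ring is an at least 3.6-fold lower number from compound 2 to compound 3 (0.56 log units; beyond the scatter), chloro in place of methyl, and it lies beyond the scatter. Going by the values given here, no measured compound carries fluoro, so this step shows only that the ring's substituent can matter. A small move towards weaker inhibition is expected, with wide uncertainty: a 1.6-fold higher number from compound 3 to compound 4 (0.22 log units; within the scatter). Compound 4 is estimated at 9000 nM, within an expected range of 3500 nM to 20000 nM.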

Compound 4, half-maximal inhibitory concentration: > 20000 nM
Compound 4 ended at the assay's limit; the forecaster's own chance of this, stated with the estimate: 25%; at least 2.2-fold (0.34 log units) between middle value and limit.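

In this assay, 4-fluorophenyl in place of 2-chlorophenyl on the amine nitrogen gives an at least 3.6-fold higher number from compound 3 to compound 4 (0.56 log units; beyond the scatter), so a change of the whole substituted ring at this position, and not only chloro against methyl, moves the number beyond the scatter. Among the compounds shown, only those with 2-chlorophenyl give values that are not limits. The step from compound 2 to compound 4 cannot be read because both values are limits: the limit of > 20000 nM in this assay, at which 2 of the 4 values shown sit.

On these data alone, it stays open whether the chlorine or its ring position matters more. 2-Fluorophenyl and 4-chlorophenyl at this nitrogen would separate the two.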